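The source may hold more compounds than are shown below. What is called first, only, known or untested is meant among the compounds shown, and "the series" means these compounds.

Measured so far in a toxicity assay on HepG2 2.2.15 cells (Homo sapiens) for cytotoxicity, read by CellTiter-Glo; on this read-out lower numbers stand for higher toxicity in this test and higher numbers for lower toxicity in this test:
- compound 1 `O=C1OC(c2ccccc2)CN1c1cnn2c1CN(C(=O)Nc1cc(F)c(F)c(F)c1)C(C1CC1)C2`: 7410 nM
- compound 2 `O=C1NC(c2ccccc2)CN1c1cnn2c1CN(C(=O)Nc1cc(F)c(F)c(F)c1)C(C1CC1)C2`: 38500 nM
- compound 3 `O=C1CC(c2ncco2)CN1c1cnn2c1CN(C(=O)Nc1cc(F)c(F)c(F)c1)C(C1CC1)C2`: a limit of this assay, > 200000 nM

Compound 1 holds the lowest of the two numbers read in this assay. Its nearest measured neighbour is compound 2, reached by a 5.2-fold higher number from compound 1 to compound 2 (0.72 log units; beyond the scatter). Compound 3 gave only a limit, so the step of an at least 26-fold higher number from compound 1 to compound 3 (1.43 log units; beyond the scatter) is known only as a lower bound.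

Compound 4 `O=C1CC(c2nccs2)CN1c1cnn2c1CN(C(=O)Nc1cc(F)c(F)c(F)c1)C(C1CC1)C2` is not yet measured. It differs from compound 1 in one place: 2-oxo-4-(1,3-thiazol-2-yl)pyrrolidin-1-yl in place of 2-oxo-5-phenyl-1,3-oxazolidin-3-yl on an aromatic carbon.

Within the data shown here, two measured steps bear on this change. The step of an at least 26-fold higher number from compound 1 to compound 3 (1.43 log units; beyond the scatter) replaces the same group on the shared core with the closely related 4-(1,3-oxazol-2-yl)-2-oxopyrrolidin-1-yl, and the step of an at least 5.1-fold higher number from compound 2 to compound 3 (0.71 log units; beyond the scatter) reaches the same compound 3 from the other side. Both point the same way, towards far lower toxicity. Compound 4 is therefore expected to sit well above compound 1 in this assay, with a fair chance that it too reaches only a limit, as described by the limit of > 200000 nM in this assay, at which 1 of the 3 values shown sits. The expected step is a 20-fold higher number from compound 1 to compound 4 (1.31 log units; beyond the scatter). For compound 4 the estimate is 150000 nM, in the range from 40000 nM to 300000 nM.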

Compound 4, half-maximal cytotoxic concentration: 115000 nM
Compound 4: middle estimate off by 1.3-fold (0.12 log units), on the high side, within the range that was stated.
By their numbers in this assay, from the lowest: compound 1; then compound 2; then compound 4. At a limit, above all of these: compound 3.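

In this assay, compound 4 gives a number rather than a limit for a 2-oxopyrrolidin-1-yl group bearing a five-membered aromatic ring at this place on the shared core, so the large rise, a 16-fold higher number from compound 1 to compound 4 (1.19 log units; beyond the scatter), has a measured size and is not only a lower bound. This group also stands clear of the 2-oxo-4-phenylimidazolidin-1-yl group, with a 3.0-fold higher number from compound 2 to compound 4 (0.48 log units; beyond the scatter). The exchange of 1,3-oxazol-2-yl for 1,3-thiazol-2-yl, an at least 1.7-fold lower number from compound 3 to compound 4 (0.24 log units; that floor lies within the scatter), sets no firm order, because compound 3 is held only as a limit: the limit of > 200000 nM in this assay, at which 1 of the 4 values shown sits.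

The compounds shown leave open whether the rise belongs to the pyrrolidinone ring or to the aromatic ring it carries, as compound 1 and compound 4 differ in both. Going by these compounds, how a plain phenyl or a pyridin-2-yl on that same pyrrolidinone would read in this assay also stays open.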